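Ring-nitrogen isomer in the urea series: solubility outlook

This account rests on a few compounds, and the source may have more. Where it says the series, first, only, none or still open, it means among the compounds named here.

Within the two compounds measured so far, compound 2 `C[C@@H]1CN([C@@H](C)CO)C(=O)c2cccc(NC(=O)Nc3cncc4ccccc34)c2O[C@H]1CN(C)S(=O)(=O)c1ccc2c(c1)OCCO2` holds the highest number in a physicochemical assay for solubility, read by HPLC, in phosphate buffer, measured as thermodynamic solubility, with a stated time of 24 h, at pH 7.4 (on this read-out lower numbers stand for lower solubility and higher numbers for higher solubility), giving 84900 nM. Going by the values given here, compound 1 `C[C@@H]1CN([C@@H](C)CO)C(=O)c2cccc(NC(=O)NCc3cccc4ccccc34)c2O[C@H]1CN(C)S(=O)(=O)c1ccc2c(c1)OCCO2` gives 100 nM and sits at the other end, so that the step of an 850-fold higher number from compound 1 to compound 2 (2.93 log units; beyond the scatter) is the only measured step in the set. Compound 3 `C[C@@H]1CN([C@@H](C)CO)C(=O)c2cccc(NC(=O)Nc3ccnc4ccccc34)c2O[C@H]1CN(C)S(=O)(=O)c1ccc2c(c1)OCCO2` has not been measured yet. It differs from compound 2 by quinolin-4-yl in place of isoquinolin-4-yl on an amide-type nitrogen, the two having the same atoms joined differently. Among the compounds with values here, no measured step bears directly on this exchange: the step from compound 1 to compound 2 swapped a (naphthalen-1-yl)methyl for an isoquinolin-4-yl group, changing both the ring nitrogen and the linker at once, whereas the move from compound 2 to compound 3 only relocates the ring nitrogen within an otherwise unchanged group. That single large step gives no guide to a move between two isomeric groups with the same atoms. With nothing in the set speaking for a shift, the change is expected to stay within or near the scatter, the estimated step being a 1.1-fold higher number from compound 2 to compound 3 (0.05 log units; within the scatter). Compound 3 is therefore estimated at 95000 nM, with a range from 25000 nM to 320000 nM.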

Compound 3, solubility: 30300 nM
Compound 3: middle estimate off by 3.1-fold (0.50 log units), on the high side; the measured number falls inside the stated range.
By their numbers in this assay, from the lowest: compound 1; then compound 3; then compound 2.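

In this assay, quinolin-4-yl in place of isoquinolin-4-yl on an amide-type nitrogen gives a 2.8-fold lower number from compound 2 to compound 3 (0.45 log units; beyond the scatter) and shows that relocating the ring nitrogen alone, with the heavy-atom, donor and acceptor counts of the group unchanged, moves the read-out beyond the scatter. That step remains small beside a 300-fold higher number from compound 1 to compound 3 (2.48 log units; beyond the scatter) and leaves compound 3, like compound 2, far above compound 1, so among these three compounds the large separation lies between the (naphthalen-1-yl)methyl compound and both isomers, with no compound going against it. Nothing available explains the gap between the two isomers.

The ring nitrogen and the methylene linker still change together in every step away from compound 1, so a naphthalen-1-yl group or an (isoquinolin-4-yl)methyl group on the same amide-type nitrogen would be needed to separate their contributions. From the compounds shown here alone, whether the gap between the isomers persists with a further amine, such as a dimethylamino group, on the quinolin-4-yl group also remains open.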